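The source may hold more compounds than are shown below. What is called first, only, known or untested is meant among the compounds shown, and "the series" means these compounds.

The two measured compounds share one core. Among the compounds with values here, compound 1 `O=C(O)Cc1sc(C(c2ccccc2)c2ccc(O)cc2)nc1-c1ccc(F)cc1` and compound 2 `N#Cc1ccc(-c2nc(C(c3ccc(F)cc3)c3ccc(F)cc3)sc2CC(=O)O)cc1` differ from each other in more than one place, so no single step joins them. In an in vitro assay on HEK385-7 cells for displacement of a labelled ligand from prostaglandin D2 receptor 2 (Homo sapiens) (on this read-out lower numbers stand for stronger inhibition and higher numbers for weaker inhibition), compound 1 gives 3.4 nM, while compound 2 gives 150 nM. Of the two numbers in hand, compound 2 stands at the higher one, and its distance from compound 1 lies well beyond the usual scatter of this assay.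

Compound 3 `O=C(O)Cc1sc(C(c2ccc(F)cc2)c2ccc(F)cc2)nc1-c1cc(F)nc(F)c1` has not yet been measured in this assay. It differs from compound 2 in a single place: 2,6-difluoropyridin-4-yl in place of 4-cyanophenyl on an aromatic carbon. Nothing measured isolates this exchange, and compound 1 differs from compound 2 in two places at once, so the value of compound 1 , 3.4 nM, cannot be assigned to either change alone. A cautious reading therefore sees compound 3 expected to give about 70 nM, with a range from 20 nM to 250 nM. The step expected from this estimate, a 2.1-fold lower number from compound 2 to compound 3 (0.33 log units; beyond the scatter), points toward lower numbers but is modest and may not exceed the scatter.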

Compound 3, half-maximal inhibitory concentration: 5.4 nM
Beside the measured number, compound 3's estimate is 13-fold (1.11 log units) above it, and the stated range ends above it.
By their numbers in this assay, from the lowest: compounds 1 and 3 (each within the scatter of the next); then compound 2.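

Within the data shown here, at the aromatic carbon next to the ring nitrogen and next to the ring atom that bears a carboxymethyl group, the exchange of 4-cyanophenyl for 2,6-difluoropyridin-4-yl gives a 28-fold lower number from compound 2 to compound 3 (1.44 log units; beyond the scatter) in this assay, the first reading of a change at this position alone, and it shows that this place on the shared core is far from indifferent to the ring it carries. The two groups match in heavy atoms, hydrogen-bond donors, hydrogen-bond acceptors and net charge, so those counts do not separate them; they differ in a ring with one hetero atom and two fluorine atoms against a ring of carbon only with a nitrile. Nothing given here bears on the reason for this step.

Which part of the exchange carries the step stays open, and a plain pyridin-4-yl group without fluorine at this position would begin to separate the ring nitrogen from the two fluorine atoms. Also open, from the compounds shown here alone, is whether a step of this size would hold with the other substituents on the shared core, such as the 4-hydroxyphenyl group of compound 1.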